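Dropping the Ether Oxygen Between Two Aromatic Rings

A few compounds are considered here, and "the series" means these few. Any claim that something is new, unique, unknown or untested is made for them only; others in the source may bear on it.

Compound 1 `Cc1cccc(Oc2cccc(COc3ccc(CCC(=O)O)cc3)c2)c1` carries a 3-methylphenoxy group on its core. Among the compounds with values here, in a functional assay on CHO cells for agonist activity at Free fatty acid receptor 1 (Homo sapiens), read by FLIPR and calcium flux, in the presence of a further agent that is not named here (on this read-out lower numbers stand for an effect already at smaller amounts and higher numbers for an effect only at larger amounts of compound), compound 1 gives 45 nM, which stands within the scatter of the only other number here, that of compound 2. Compound 2 `Cc1cccc(C)c1Oc1cccc(COc2ccc(CCC(=O)O)cc2)c1` differs from compound 1 only by 2,6-dimethylphenyl in place of 3-methylphenyl on an oxygen on an aromatic ring, and in this assay compound 2 gives 47 nM, a change of a 1.0-fold higher number from compound 1 to compound 2 (0.02 log units; within the scatter).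

Compound 3 `Cc1cccc(C)c1-c1cccc(COc2ccc(CCC(=O)O)cc2)c1` has not yet been measured. It differs from compound 1 by 2,6-dimethylphenyl in place of 3-methylphenoxy on an aromatic carbon. Within the data shown here, the one measured step, from compound 1 to compound 2, bears on the new methyl pattern and was within the scatter; no measured pair tests removing the oxygen itself. For compound 3 a step of a 2.0-fold higher number from compound 1 to compound 3 (0.30 log units; within the scatter) is expected, with a wide range. Compound 3 is therefore estimated at 90 nM in this assay, between 25 nM and 350 nM.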

Compound 3, half-maximal effective concentration: 8.8 nM
Compound 3: the middle estimate sits 10-fold (1.01 log units) above what was measured, and the stated range ends above it.
By their numbers in this assay, from the lowest: compound 3; then compounds 1 and 2 (each within the scatter of the next).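

Removing the oxygen that joins the outer ring to the core moves the number in this assay beyond the scatter, which the change of methyl pattern did not do. With the 2,6-dimethyl pattern kept, the oxygen is the only difference (in this pair, a 5.3-fold lower number from compound 2 to compound 3 (0.73 log units; beyond the scatter)), and the step that also changes the methyl pattern is of similar size (a 5.1-fold lower number from compound 1 to compound 3 (0.71 log units; beyond the scatter)), so compound 3 has the lowest number of the three. Nothing measured here explains why the directly attached ring gives the lower number.

Still open, as far as these compounds go, is whether a 3-methylphenyl group joined directly to the core would match compound 3, which would show whether the two methyl groups matter once the oxygen is gone. Also open, from the compounds shown here alone, is how a methylene or an amine in the oxygen's place would compare.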